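The source may report more compounds than this note shows. Statements on the series, on what has been measured and on what is new or still open speak of the compounds shown alone.

Working notes on the series. Compound 1 `COc1cc(-c2cc(/C=C/C(=O)c3ccc(N)cc3)[nH]n2)cc(OC)c1OC` gives 4330 nM in a functional assay on Hs-578T cells (Homo sapiens) for inhibition, read by sulforhodamine B assay, with a stated time of 48 h; on this read-out lower numbers stand for stronger inhibition of growth and higher numbers for weaker inhibition of growth. For the measured compounds named here, compound 2 `COc1cc(-c2cc(/C=C/C(=O)c3ccc(Cl)c(Cl)c3)[nH]n2)cc(OC)c1OC`, in this assay, gives 16600 nM, the highest number of the three measured so far: compound 1 is its nearest neighbour at a 3.8-fold higher number from compound 1 to compound 2 (0.58 log units; beyond the scatter) in reverse, and compound 3 `COc1ccc(-c2cc(/C=C/C(=O)c3cc(OC)c(OC)c(OC)c3)[nH]n2)cc1OC`, with 2910 nM, is the furthest, the two values being separated by a gap that lies beyond the scatter. Compound 4 `COc1ccc(C(=O)/C=C/c2cc(-c3cc(OC)c(OC)c(OC)c3)n[nH]2)cc1` has not yet been measured. It differs from compound 2 in one place: 4-methoxyphenyl in place of 3,4-dichlorophenyl on a carbonyl carbon.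

Going by the values given here, the only measured step that touches the same position is the one from compound 1 to compound 2, a 3.8-fold higher number from compound 1 to compound 2 (0.58 log units; beyond the scatter), a modest rise in the number when 3,4-dichlorophenyl replaced 4-aminophenyl on the carbonyl carbon. Among the compounds with values here, compound 4 undoes the dichloro substitution and puts in 4-methoxyphenyl instead; no measured pair shows 4-methoxyphenyl directly, so the size of the step is uncertain, but the direction is expected to be downward, since compound 2 sits at the high end and the one comparable step, a 3.8-fold higher number from compound 1 to compound 2 (0.58 log units; beyond the scatter), went the other way when the dichlorophenyl entered. The expected step is a 2.6-fold lower number from compound 2 to compound 4 (0.41 log units; beyond the scatter), a move back toward, though not necessarily reaching, compound 1.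

For compound 4 the estimate in this assay is 6500 nM, with a range from 2500 nM to 16000 nM.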

Compound 4, concentration for 50% growth inhibition: 3600 nM
Estimate against measurement, compound 4: 1.8-fold (0.26 log units) above; low and high end bracket the measured number.
By their numbers in this assay, from the lowest: compounds 3, 4 and 1 (each within the scatter of the next); then compound 2.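

In this assay, 4-methoxyphenyl in place of 3,4-dichlorophenyl on the carbonyl carbon gives a 4.6-fold lower number from compound 2 to compound 4 (0.66 log units; beyond the scatter), so the high number of compound 2 does not follow from every change away from 4-aminophenyl at this position. Methoxy in place of amino on an aromatic carbon gives a 1.2-fold lower number from compound 1 to compound 4 (0.08 log units; within the scatter), which lies within the scatter, so 4-aminophenyl and 4-methoxyphenyl cannot be told apart here and a free amino group is not needed to keep the number at this level. Among the three compounds that differ only in this group, the 3,4-dichlorophenyl of compound 2 is the one that stands apart, a reading that rests on these three alone.

The compounds shown leave open whether the high number of compound 2 goes with one chlorine or with both, and how an unsubstituted phenyl or a 4-chlorophenyl on the same carbonyl carbon would compare. No supporting data are at hand to explain the behaviour of this position.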